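The source may report more compounds than this note shows. Statements on the series, on what has been measured and on what is new or still open speak of the compounds shown alone.

In a functional assay on OVCAR-3 cells (Homo sapiens) for antiproliferative activity, read by spectrophotometry, with a stated time of 2 days (on this read-out lower numbers stand for stronger inhibition of growth and higher numbers for weaker inhibition of growth), compound 1 `CC(=O)N1CCN(c2ccc(Nc3ncc(C(F)(F)F)c(N4Cc5cccc(N(C)S(C)(=O)=O)c5C4)n3)cc2)CC1` gives 970 nM. Compound 2 `Cc1cc(F)ccc1Nc1ncc(C(F)(F)F)c(N2Cc3cccc(N(C)S(C)(=O)=O)c3C2)n1` reads > 30000 nM, which is a limit of the assay and not a number. Compound 2 therefore stands at the limit of > 30000 nM in this assay, at which 1 of the 2 values shown sits. Compound 3 `CN(c1cccc2c1CN(c1nc(Nc3ccc(C(F)(F)F)cc3)ncc1C(F)(F)F)C2)S(C)(=O)=O` carries 4-(trifluoromethyl)phenyl in place of 4-fluoro-2-methylphenyl on a nitrogen on an aromatic ring. Going by the values given here, no measured pair of compounds shows what this exchange does. The expected change is an at least 1.5-fold lower number from compound 2 to compound 3 (0.17 log units; that floor lies within the scatter), with no shift beyond the scatter estimated. Compound 3 is estimated at 20000 nM, with an expected range of 6000 nM to 30000 nM.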

Compound 3, concentration for 50% growth inhibition: > 30000 nM
Compound 3: a limit, no number; the forecaster's own chance of this, stated with the estimate: 55%; at least 1.5-fold (0.17 log units) between middle value and limit.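

In this assay compound 3 gives a limit, not a number, and since compound 2 also gives a limit, the two steps from compound 2 cannot be read. The readable step is trifluoromethyl in place of 4-acetylpiperazin-1-yl on an aromatic carbon, which gives an at least 30-fold higher number from compound 1 to compound 3 (1.49 log units; beyond the scatter). Only compound 1 carries a number, and the rest sit at the ceiling: the limit of > 30000 nM in this assay, at which 2 of the 3 values shown sit.

On these data alone, whether a morpholine or a simple dimethylamino group on an aromatic carbon in the same place would restore the growth inhibition seen with compound 1 remains open.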